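Hydrazone ureas: dibromohydroxyphenyl in place of phenyl

The source may hold more compounds than are shown below. What is called first, only, known or untested is meant among the compounds shown, and "the series" means these compounds.

Measured so far:
compound 1 `O=C(N/N=C/c1ccccc1)Nc1ccc(Oc2ccnc3[nH]ccc23)c(F)c1`: 2380 nM
compound 2 `N#Cc1ccc(/C=N/NC(=O)Nc2ccc(Oc3ccnc4[nH]ccc34)c(F)c2)cc1`: "not active" (no number reported)
compound 3 `O=C(N/N=C/c1ccc(O)cc1O)Nc1ccc(Oc2ccnc3[nH]ccc23)c(F)c1`: 48000 nM

In a functional assay on MCF7 cells (Homo sapiens) for antiproliferative activity, read by MTT assay, with a stated time of 72 h (on this read-out lower numbers stand for stronger inhibition and higher numbers for weaker inhibition), compound 1 gives 2380 nM, the lowest of the two numbers reported; compound 3 gives 48000 nM, and compound 2 is reported as not active without a number. Among the compounds with values here, the only measured step, a 20-fold higher number from compound 1 to compound 3 (1.30 log units; beyond the scatter), shows that a substituted ring on the carbon with the double bond to nitrogen raises the number markedly. Compound 4 `O=C(N/N=C/c1cc(Br)c(O)c(Br)c1)Nc1ccc(Oc2ccnc3[nH]ccc23)c(F)c1` carries the change (3,5-dibromo-4-hydroxyphenyl in place of phenyl on a carbon with a double bond to nitrogen). Compound 3 gives 48000 nM, and compound 4 likewise bears a hydroxyphenyl on that carbon, so a rise is expected, a 6.3-fold higher number from compound 1 to compound 4 (0.80 log units; beyond the scatter). Compound 4 is therefore estimated at 15000 nM, within a range of 4000 nM to 60000 nM.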

Compound 4, half-maximal inhibitory concentration: "not active" (no number reported)
Compound 4 has no reported number here; no gap can be computed for the estimate.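

In this assay compound 4 is reported as not active without a number, so no new step can be read against compound 1 or compound 3. No measured evidence bears on this result. The compounds shown leave open where compound 4 stands numerically relative to compound 1 and compound 3.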